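The source may report more compounds than this note shows. Statements on the series, on what has been measured and on what is new or still open speak of the compounds shown alone.

In a functional assay on CHP-134 cells (Homo sapiens) for antiproliferative activity, with a stated time of 72 h (a higher number here means a weaker inhibitor, a lower number a stronger inhibitor), compound 2 `O=C(CCN(Cc1ccc(C(=O)NO)cc1)C(=O)c1ccccc1)NCc1ccccc1` gives the highest number of the three measured compounds, 4680 nM, while compound 1 `Cc1cc(C)cc(C(=O)N(CCC(=O)NCc2ccccc2)Cc2ccc(C(=O)NO)cc2)c1` gives 2030 nM. Compound 4 `CN(C)c1ccc(C(=O)N(CCC(=O)NCc2ccccc2)Cc2ccc(C(=O)NO)cc2)cc1` differs from compound 2 by one change: dimethylamino in place of hydrogen on an aromatic carbon, para to a large group. Among the compounds with values here, the one measured step on this ring, a 2.3-fold higher number from compound 1 to compound 2 (0.36 log units; beyond the scatter), is modest and shows that substituents here can shift the number. Compound 3 `CN(C)c1ccc(C(=O)N(CCC(=O)NCc2ccc(Cl)cc2)Cc2ccc(C(=O)NO)cc2)cc1`, at 610 nM, already carries dimethylamino, but it also differs from compound 4 elsewhere, so it is only a loose guide. A somewhat larger drop than that modest step is therefore expected, and the estimated step is a 3.1-fold lower number from compound 2 to compound 4 (0.49 log units; beyond the scatter). Compound 4 is expected near 1500 nM, with an estimated range of 600 nM to 3500 nM.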

Compound 4, half-maximal inhibitory concentration: 1160 nM
Compound 4: middle estimate off by 1.3-fold (0.11 log units), on the high side, within the range that was stated.
By their numbers in this assay, from the lowest: compounds 3, 4 and 1 (each within the scatter of the next, the first and the last beyond it); then compound 2.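

In this assay, within the data shown here, dimethylamino on an aromatic carbon, para to a large group, gives a 4.0-fold lower number from compound 2 to compound 4 (0.61 log units; beyond the scatter) and is the first single change at this place to start from the unsubstituted benzoyl compound with a step of this size. The ring change gives a 1.8-fold lower number from compound 1 to compound 4 (0.24 log units; within the scatter) and so does not separate 4-(dimethylamino)phenyl from 3,5-dimethylphenyl, while hydrogen in place of chloro gives a 1.9-fold higher number from compound 3 to compound 4 (0.28 log units; within the scatter) and likewise stays within the scatter. On these data alone, whether an amino group, a methoxy group or a carboxylic acid at this place would give a similar step stays open. No measurement here explains the step to compound 4.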